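A few compounds are considered here, and "the series" means these few. Any claim that something is new, unique, unknown or untested is made for them only; others in the source may bear on it.

Compound 1, `COc1ccc(-n2nc(C(N)=O)nc2-c2cc(OC)c(OC)c(OC)c2)cc1`, gives 59%.
Compound 2, `CNC(=O)c1nc(-c2cc(OC)c(OC)c(OC)c2)n(-c2ccc(OC)cc2)n1`, gives 74%.
Compound 3, `COc1ccc(-n2nc(C(=O)Nc3ccccc3C)nc2-c2cc(OC)c(OC)c(OC)c2)cc1`, gives 30%.

In a functional assay on the whole organism for inhibition, with Rattus norvegicus as the target, read by paw edema, with stated times of 30 min and 2 h, at a dose of 0.28 mmol/kg by the oral route (on this read-out lower numbers stand for less inhibition and higher numbers for more inhibition at the one dose given (going by the name of the read-out)), compound 2 stands highest of the three measured compounds. Its nearest neighbour is compound 1, with the step of a number 15 percentage points higher from compound 1 to compound 2 (beyond the scatter), and its furthest is compound 3, with the step of a number 44 percentage points lower from compound 2 to compound 3 (beyond the scatter).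

The compound that follows is compound 4, `COc1ccc(-n2nc(C(=O)Nc3ccc(O)cc3)nc2-c2cc(OC)c(OC)c(OC)c2)cc1`. It differs from compound 2 in one place: 4-hydroxyphenyl in place of methyl on an amide-type nitrogen.

Two of the measured steps bear on this change, since both put an aryl group on the same amide-type nitrogen. From compound 2 the step of a number 44 percentage points lower from compound 2 to compound 3 (beyond the scatter) is the closest comparison, as it also starts from the methyl. The step of a number 29 percentage points lower from compound 1 to compound 3 (beyond the scatter) points the same way from the unsubstituted amide. Among the compounds with values here, both aryl steps are beyond the scatter and downward, so for compound 4 a fall in this assay is expected, though with only one aryl example on record the size of that fall is uncertain. Compound 4 is therefore estimated at 38%, in the range 20% to 58%, which would mean an expected step of a number 36 percentage points lower from compound 2 to compound 4 (beyond the scatter).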

Compound 4, a percentage reported as inhibition, in the whole organism at one dose (the size of the read-out at that dose, not a potency): 35%
Compound 4: middle estimate off by 3 percentage points, on the high side, and the stated range covers the measured number.
By their numbers in this assay, from the lowest: compounds 3 and 4 (each within the scatter of the next); then compound 1; then compound 2.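

In this assay a second aryl group on the amide-type nitrogen also lowers the number, with a number 39 percentage points lower from compound 2 to compound 4 (beyond the scatter) and a number 24 percentage points lower from compound 1 to compound 4 (beyond the scatter) as its two steps, so the loss seen earlier is not confined to 2-methylphenyl. The two aryl amides do not separate, with a number 5 percentage points higher from compound 3 to compound 4 (within the scatter) between them, which means that swapping 2-methylphenyl for 4-hydroxyphenyl, and so adding the hydroxyl, gives no readable change at this one dose. The measurements offer no information on why the aryl amides fall short of the methyl amide of compound 2.

The compounds shown leave open whether a longer chain than methyl on this nitrogen, such as ethyl or propyl, would hold the number of compound 2 or whether the fall would already begin there. They also leave open what a benzyl group, an unsubstituted phenyl, or a phenyl carrying an amine or a carboxylic acid in place of the hydroxyl would give on the same nitrogen.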